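From amino to propoxy in a cytotoxicity series

The source may hold more compounds than are shown below. What is called first, only, known or untested is meant among the compounds shown, and "the series" means these compounds.

In a functional assay on K562 cells (Homo sapiens) for cytotoxicity (a higher number here means a weaker inhibitor, a lower number a stronger inhibitor), compound 1 `CCC(CO)Nc1nc(NCc2cccc(O)c2)c2nc(Cl)n(C(C)C)c2n1` gives 27000 nM as its value, while compound 2 `CCC(CO)Nc1nc(NCc2ccccc2)c2nc(N)n(C(C)C)c2n1` gives 80000 nM and so holds the higher of the two numbers, a gap beyond the scatter. Compound 3 `CCCOc1nc2c(NCc3ccccc3)nc(NC(CC)CO)nc2n1C(C)C` departs from compound 2 by one change, propoxy in place of amino on an aromatic carbon at that single place. Among the compounds with values here, no measured pair shows this change alone, so only a modest move toward a lower number is expected in this assay and the estimated step is a 2.7-fold lower number from compound 2 to compound 3 (0.43 log units; beyond the scatter) on that reading. For compound 3 the expected value is 30000 nM with 10000 nM to 90000 nM as its estimated range.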

Compound 3, half-maximal inhibitory concentration: 20000 nM
Beside the measured number, compound 3's estimate is 1.5-fold (0.18 log units) above it, within the range that was stated.
By their numbers in this assay, from the lowest: compounds 3 and 1 (each within the scatter of the next); then compound 2.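

Propoxy in place of amino on this aromatic carbon, between two ring nitrogen atoms, gives a 4.0-fold lower number from compound 2 to compound 3 (0.60 log units; beyond the scatter) in this assay. Within the data shown here, this is the first one-place comparison, and it shows that the cytotoxicity read-out responds to the group at this position and that the larger propoxy group brings no loss. No measurement shown accounts for the step. The compounds shown leave open whether a shorter methoxy group, a longer butoxy chain or a dimethylamino group here would move the number further, and whether the oxygen link matters.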